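This account rests on a few compounds, and the source may have more. Where it says the series, first, only, none or still open, it means among the compounds named here.

Measured so far:
- compound 1, `Cc1ccccc1NC(=O)CSc1nccn1-c1ccc(Cl)cc1`: 160000 nM
- compound 2, `COc1ccc(-n2ccnc2SCC(=O)Nc2ccccc2[N+](=O)[O-])cc1`: 161000 nM
- compound 3, `Cc1ccc(-n2ccnc2SCC(=O)Nc2ccccc2Cl)cc1`: 33700 nM

In an ADME assay on MT4 cells (Homo sapiens) for cytotoxicity, read by MTT assay (on this read-out higher numbers stand for lower toxicity in this test and lower numbers for higher toxicity in this test), compound 2 gives 161000 nM, the highest number of the three. Compound 1 gives 160000 nM, and the gap between compound 1 and compound 2 lies within the scatter, so the two are read as one level. Compound 3 gives 33700 nM, a number below that of compound 2 by more than the scatter; compound 3 also carries a chloro rather than a nitro on the aryl amide part, together with a methyl in place of the methoxy on the other aryl ring, so no single-change comparison is available.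

Compound 4, `COc1ccc(-n2ccnc2SCC(=O)Nc2ccccc2Br)cc1`, differs from compound 2 in one place: bromo in place of nitro on an aromatic carbon. Among the compounds with values here, no measured pair shows this change alone. Given that the only other halogen-bearing compound, compound 3, gives 33700 nM, a modest drop in the number for compound 4 is expected in this assay, of a size around the edge of the scatter, a 1.9-fold lower number from compound 2 to compound 4 (0.28 log units; within the scatter). Compound 4 is estimated at 85000 nM, with a range from 30000 nM to 200000 nM.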

Compound 4, half-maximal cytotoxic concentration: > 298000 nM
Compound 4: no number, only a limit; the forecaster's own chance of this, stated with the estimate: 15%; middle value at least 3.5-fold (0.54 log units) from the limit.
By their numbers in this assay, from the lowest: compound 3; then compounds 1 and 2 (each within the scatter of the next). At a limit, above all of these: compound 4.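

In this assay compound 4 gives > 298000 nM and this is a limit of the assay, not a number. Bromo in place of nitro, on an aromatic carbon ortho to a large group, gives the first single-change reading in the series: an at least 1.8-fold higher number from compound 2 to compound 4 (0.26 log units; that floor lies within the scatter) and no drop appears. With methoxy on the other aryl ring, this position carries 2-bromophenyl as well as 2-nitrophenyl without a fall in the number, while the true size of the step stays unknown: the limit of > 298000 nM in this assay, at which 1 of the 4 values shown sits.

An amine or a carboxylic acid in the same place would show whether the high number extends beyond nitro and bromo. On these data alone, what sets compound 3 at 33700 nM stays open, as compound 3 differs from compounds 1, 2 and 4 in more than one place.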